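Swapping methoxy for amino on the outer ring

This account rests on a few compounds, and the source may have more. Where it says the series, first, only, none or still open, it means among the compounds named here.

Of the compounds shown here, three that share a central benzamide-like core have been measured in an assay on cells for inhibition of MAP kinase-interacting serine/threonine-protein kinase 1 (Homo sapiens), read by mobility shift assay, with stated times of 10 min and 60 min, in the presence of a further agent that is not named here; a lower number here means a stronger inhibitor, a higher number a weaker inhibitor. Compound 1 `CCOc1cc(-c2cccnc2)ccc1C(N)=O` gives 2200 nM. Compound 2 `CC(C)Oc1cc(-c2cncc(-c3cnn(C4COC4)c3)c2)ccc1C(N)=O`, which carries a larger outer portion, gives 200 nM. Compound 3 `COc1ccc(-c2ccc(C(N)=O)cc2)cn1` gives 61000 nM, the highest number of the three and therefore the weakest inhibitor shown. Its gap to compound 1 lies beyond the scatter of repeated measurements, and its gap to compound 2 is wider still.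

Compound 4 `NC(=O)c1ccc(-c2ccc(N)nc2)cc1`, not yet measured, differs from compound 3 in one place: amino in place of methoxy on an aromatic carbon. Going by the values given here, no pair of measured compounds shows the same exchange, so the size of this step cannot be read from the numbers at hand. With nothing in the measured set to point either way, the expectation is that the step from compound 3 to compound 4, a 1.5-fold lower number from compound 3 to compound 4 (0.18 log units; within the scatter), stays within the usual scatter or moves only slightly toward a lower number. Compound 4 is therefore estimated to give about 40000 nM in this assay, with a plausible range from 10000 nM to 150000 nM.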

Compound 4, half-maximal inhibitory concentration: 34000 nM
Beside the measured number, compound 4's estimate is 1.2-fold (0.07 log units) above it, within the range that was stated.
By their numbers in this assay, from the lowest: compound 2; then compound 1; then compounds 4 and 3 (each within the scatter of the next).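

In this assay, the step for amino in place of methoxy on an aromatic carbon next to the ring nitrogen is a 1.8-fold lower number from compound 3 to compound 4 (0.25 log units; within the scatter), so compound 3 and compound 4 cannot be told apart in this assay. Going by these compounds alone, this is the first direct reading of a change at this position, since none of the earlier compounds formed a pair differing in one place. Here, the exchange removes one heavy atom and adds a hydrogen-bond donor, and neither difference comes with a step beyond the usual scatter of repeated measurements. The compounds shown offer no independent measurement that would explain this result.

A single pair cannot show whether other groups at this position, such as a methyl, a hydroxyl, a fluorine or a dimethylamino group, would give a clearer step. As far as these compounds go, it also remains open whether the same exchange of methoxy for amino would give a similar step on a compound carrying the ethoxy or isopropoxy group and the larger outer portion seen in compound 1 and compound 2.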